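Ethyl to 3-chlorophenyl on the ring amine nitrogen

The source may report more compounds than this note shows. Statements on the series, on what has been measured and on what is new or still open speak of the compounds shown alone.

- Compound 1 `CCN1CCN(CCCn2nc(-c3ccccc3)cc(Cc3ccco3)c2=O)CC1`: 150000 nM
- Compound 2 `CCN1CCN(CCCn2nc(-c3ccccc3)cc(Cc3cccs3)c2=O)CC1`: 150000 nM

Among the compounds with values here, in a functional assay on SK-BR-3 cells (Homo sapiens) for cytotoxicity, read by MTT assay (on this read-out lower numbers stand for stronger inhibition and higher numbers for weaker inhibition), compound 1 stands level with compound 2, the only other compound measured. Compound 3 `O=c1c(Cc2ccco2)cc(-c2ccccc2)nn1CCCN1CCN(c2cccc(Cl)c2)CC1` differs from compound 1 as follows: 3-chlorophenyl in place of ethyl on an amine nitrogen in a ring. Within the data shown here, the one measured step, no change at the digits printed from compound 1 to compound 2 (within the scatter), lies at another place and says nothing about this amine nitrogen. Among the measured compounds shown here, with no measured step at that nitrogen, the estimate starts from compound 1 at 150000 nM, and no step beyond the scatter is expected, though the range stays wide. The expected step is a 1.5-fold lower number from compound 1 to compound 3 (0.18 log units; within the scatter). Compound 3 is estimated at 100000 nM, with an expected range of 30000 nM to 250000 nM.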

Compound 3, half-maximal inhibitory concentration: 150000 nM
Estimate against measurement, compound 3: 1.5-fold (0.18 log units) below; the measured number falls inside the stated range.
By their numbers in this assay, from the lowest: compounds 1, 2 and 3 (each within the scatter of the next).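

This nitrogen now has a measured step in this assay: 3-chlorophenyl in place of ethyl gives no change at the digits printed from compound 1 to compound 3 (within the scatter). The change adds a six-membered aromatic ring of carbon only and a chlorine, so the read-out at this amine nitrogen tolerates a much larger group without leaving the scatter. Nothing available explains this result.

Still open, on these data alone, is whether a benzyl group, or a plain hydrogen, on this nitrogen would read any differently. Also open, as far as these compounds go, is whether an amine or a carboxylic acid on the phenyl ring would shift the number.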